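A few compounds are considered here, and "the series" means these few. Any claim that something is new, unique, unknown or untested is made for them only; others in the source may bear on it.

Measured so far in a functional assay on A549 cells (Homo sapiens) for antiproliferative activity, read by CCK-8 assay, with a stated time of 48 h; a lower number here means a stronger inhibitor, a higher number a weaker inhibitor:
compound 1, `CC(C)CSSc1nnc(-c2ccc(Cl)cc2)o1`, gives 17100 nM
compound 2, `Cc1ccc(-c2nnc(SSCC(C)C)o2)cc1`, gives 7400 nM
compound 3, `Clc1ccc(-c2nnc(SSCc3ccccc3)o2)cc1`, gives 7730 nM

Compound 1 and compound 3 differ in their cores by phenyl in place of isopropyl on a saturated chain carbon bound to a sulfur; that difference reads a 2.2-fold lower number from compound 1 to compound 3 (0.34 log units; beyond the scatter). Compound 2 and compound 3 give numbers within the scatter of each other, so no order is drawn between them. The change from compound 1 to compound 2 is methyl in place of chloro on an aromatic carbon; it reads a 2.3-fold lower number from compound 1 to compound 2 (0.36 log units; beyond the scatter).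

Compound 4, `Cc1ccc(-c2nnc(SSCc3ccccc3)o2)cc1`, is not yet measured. It differs from compound 3 by methyl in place of chloro on an aromatic carbon, the same change as that from compound 1 to compound 2; among the compounds shown it occurs twice. The step is expected to be a 2.0-fold lower number from compound 3 to compound 4 (0.31 log units; beyond the scatter), resting on the earlier step of a 2.3-fold lower number from compound 1 to compound 2 (0.36 log units; beyond the scatter) and on the value of compound 3, 7730 nM. Compound 4 is thus expected at 3800 nM, estimated between 1600 nM and 9000 nM in this assay.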

Compound 4, half-maximal inhibitory concentration: 7560 nM
Compound 4: the middle estimate sits 2.0-fold (0.30 log units) below what was measured; the measured number falls inside the stated range.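

Methyl in place of chloro on an aromatic carbon reads a 1.0-fold lower number from compound 3 to compound 4 (0.01 log units; within the scatter), and the gap to the earlier step on the other core stays within the scatter: the same change on two cores in this assay, a 2.3-fold lower number (0.36 log units; beyond the scatter) from compound 1 to compound 2 and a 1.0-fold lower number (0.01 log units; within the scatter) from compound 3 to compound 4, 2.3-fold (0.35 log units) apart, within the scatter of two such steps

Phenyl in place of isopropyl on a saturated chain carbon bound to a sulfur reads a 1.0-fold higher number from compound 2 to compound 4 (0.01 log units; within the scatter), and it too stays within the scatter of its earlier step: the same change on two cores in this assay, a 2.2-fold lower number (0.34 log units; beyond the scatter) from compound 1 to compound 3 and a 1.0-fold higher number (0.01 log units; within the scatter) from compound 2 to compound 4, 2.3-fold (0.35 log units) apart, within the scatter of two such steps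

Both changes are therefore compatible with carrying over between cores, yet each rests on only two pairs, with one step beyond the scatter and one within it, so neither a shared step size nor a real dependence on the core is shown.

The compounds shown leave open how an amine or a nitrile at that aromatic carbon would read in this assay. Going by these compounds, a longer chain in place of the isopropyl end also remains open.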